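Exchanging the amine on a shared core

This account rests on a few compounds, and the source may have more. Where it says the series, first, only, none or still open, it means among the compounds named here.

Three compounds share one core, each carrying an amino-type group and a substituted benzyl group: compound 1 `CNc1ncnc2c1ncn2Cc1ccccc1C(F)(F)F`, compound 2 `CNc1ncnc2c1ncn2Cc1c(F)cccc1F` and compound 3 `CCCNc1ncnc2c1ncn2Cc1ccccc1F`. In a functional assay on the whole organism with Rattus norvegicus as the target, in the maximal electroshock model (on this read-out lower numbers stand for an effect already at smaller amounts and higher numbers for an effect only at larger amounts of compound), compound 1 gives 20 mg/kg, compound 2 gives 2 mg/kg and compound 3 gives 5.1 mg/kg. Compound 3 thus stands second highest of the three, beyond the scatter from both compound 2 and compound 1.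

Compound 4 `CN(C)c1ncnc2c1ncn2Cc1ccccc1F` has not yet been measured. It differs from compound 3 in one place: dimethylamino in place of propylamino on an aromatic carbon. For the measured compounds named here, no pair of measured compounds shows a change of this kind, so nothing measured here points to a direction; a small step toward a higher dose, or none beyond the scatter, seems most plausible. Compound 4 is therefore expected in this assay at 8 mg/kg, within a range from 3 mg/kg to 20 mg/kg. The expected step is a 1.6-fold higher number from compound 3 to compound 4 (0.20 log units; within the scatter).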

Compound 4, dose for half-maximal effect: 8.8 mg/kg
Compound 4: the middle estimate sits 1.1-fold (0.04 log units) below what was measured; low and high end bracket the measured number.
By their numbers in this assay, from the lowest: compound 2; then compounds 3 and 4 (each within the scatter of the next); then compound 1.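

On this aromatic carbon of the shared core, dimethylamino in place of propylamino gives a 1.7-fold higher number from compound 3 to compound 4 (0.24 log units; within the scatter) in this assay, so the two compounds cannot be told apart on this read-out. The exchange removes the hydrogen-bond donor of the amine and changes the chain, yet the dose stays within the scatter. Nothing measured here bears on why this is so.

Still open, from the compounds shown here alone, is how a plain amino group or a morpholine ring would behave at this carbon. Also open, going by these compounds, is whether methylamino with this same benzyl group would separate the effect of the donor from that of the chain.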